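The source may hold more compounds than are shown below. What is called first, only, known or untested is meant among the compounds shown, and "the series" means these compounds.

Among the measured compounds shown here, only two compounds sharing one core have numbers so far in a functional assay on KB cells (Homo sapiens) for antiproliferative activity, read by colorimetric assay and MTT assay; on this read-out lower numbers stand for stronger inhibition and higher numbers for weaker inhibition. Compound 1 `N#Cc1ccc(S(=O)(=O)Nc2cccc3c(Cl)c[nH]c23)cc1` gives 11 ug/mL, and compound 2 `Nc1ccc(S(=O)(=O)Nc2cccc3c(Cl)c[nH]c23)cc1` gives 10 ug/mL. Compound 2 therefore stands level with compound 1, and neither can be called the better of the pair. Compound 3 `COc1ccc(NS(=O)(=O)c2ccc(N)cc2)c2[nH]cc(Cl)c12` has not yet been measured. It differs from compound 2 by one change: methoxy in place of hydrogen on an aromatic carbon. This puts methoxy in place of hydrogen on an aromatic carbon, on a six-membered aromatic ring of carbon only, para to a large group.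

For the measured compounds named here, the only measured step is a 1.1-fold lower number from compound 1 to compound 2 (0.04 log units; within the scatter), which put amino in place of cyano and stayed within the scatter. That step involves different groups, so it says little directly about methoxy. With no measured methoxy comparison, only a small change can reasonably be expected, and no shift beyond the scatter is predicted, though the uncertainty is wide. The expected step is a 1.4-fold lower number from compound 2 to compound 3 (0.15 log units; within the scatter). For compound 3 the estimated value is 7 ug/mL, with an expected range from 1.5 ug/mL to 25 ug/mL.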

Compound 3, half-maximal inhibitory concentration: 20 ug/mL
Compound 3: middle estimate off by 2.9-fold (0.46 log units), on the low side; measured number inside the range.
By their numbers in this assay, from the lowest: compounds 2, 1 and 3 (each within the scatter of the next).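

Among the compounds shown here, compound 3 is the first compound here that carries anything other than hydrogen on this aromatic carbon of the shared core, and in this assay the change gives a 2.0-fold higher number from compound 2 to compound 3 (0.30 log units; within the scatter). Methoxy, with its 2 heavy atoms, can therefore sit on this carbon, para to a large group, and the result still cannot be told apart from that of compound 2, so this one change shows no effect beyond the ordinary spread of repeated measurements. Nothing measured here offers any explanation of this result, whether of how the cells respond or of what the methoxy group does.

On these data alone, it remains open whether a hydroxyl, an amine or a longer chain such as ethoxy on the same carbon would also stay within the scatter, or would instead produce a clear step in either direction. As far as these compounds go, it is also open whether methoxy on this carbon would give a similar result with a nitrile in place of the amino group, as in compound 1.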